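From Methylamino to Benzylamino in a Rat Assay

The compounds below may be only part of what the source reports. "The series", "measured", "known", "first", "only" and "open" are said of these compounds alone.

The compounds were tested in a functional assay on the whole organism with Rattus norvegicus as the target, at a dose of 40 mg/kg by the intraperitoneal route; a lower number here means less inhibition, a higher number more inhibition at the dose given (going by the name of the read-out). Compound 1 `CNC(=O)Nc1c(C)nc2c(OCc3ccccc3)cccn12` gives 22%. For the measured compounds named here, compound 2 `CNc1c(C)nc2c(OCc3ccccc3)cccn12` gives 55%, the highest of the two numbers measured so far, with compound 1 as its nearest neighbour. Going by the values given here, the single measured step, a number 33 percentage points higher from compound 1 to compound 2 (beyond the scatter), came from methyl in place of methylcarbamoyl on a nitrogen on an aromatic ring.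

Compound 3 `Cc1nc2c(OCc3ccccc3)cccn2c1NCc1ccccc1` has not yet been measured in this assay. It differs from compound 2 by phenyl in place of hydrogen on a saturated chain carbon bound to a nitrogen on an aromatic ring; cut one bond further out, the change reads methyl to benzyl, methylamino to benzylamino. Among the compounds with values here, the one measured step touches the same nitrogen, but it is a different exchange and does not show what phenyl on the saturated chain carbon does. Within the data shown here, no measured pair speaks to this change, so there is nothing in the data to set a direction. The step of a number 5 percentage points lower from compound 2 to compound 3 (within the scatter) is therefore expected to stay within the scatter. Compound 3 is estimated at 50%, within a range from 25% to 75%.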

Compound 3, a percentage reported as inhibition, in the whole organism at one dose (the size of the read-out at that dose, not a potency): 48%
For compound 3 the middle estimate is 2 percentage points above the measured one, within the range that was stated.
By their numbers in this assay, from the lowest: compound 1; then compounds 3 and 2 (each within the scatter of the next).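

Benzylamino in place of methylamino gives a number 7 percentage points lower from compound 2 to compound 3 (within the scatter) in this assay and so shows that phenyl on a saturated chain carbon bound to a nitrogen on an aromatic ring leaves a number that cannot be told apart from that of the methylamino compound. The earlier compounds had shown only methyl in place of methylcarbamoyl on this nitrogen, whereas benzyl in place of methylcarbamoyl gives a number 26 percentage points higher from compound 1 to compound 3 (beyond the scatter) and so shows that the higher number over the methylcarbamoyl compound is not tied to methyl alone, at least across these three compounds. Nothing available bears on why the number holds when the phenyl ring enters.

From the compounds shown here alone, what stays open is whether a longer chain on this nitrogen, such as phenethyl, would give a number in the same range as benzyl and methyl. Going by these compounds, it is also open whether a carboxylic acid or an amine on the phenyl ring of the benzyl group would keep the number there, and whether the unsubstituted amine would do the same.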